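The source may hold more compounds than are shown below. What is called first, only, known or untested is meant among the compounds shown, and "the series" means these compounds.

Compound 1 `Cc1cn([C@H]2C[C@H](N=[N+]=[N-])[C@@H](COP(=O)(O)Oc3ccccc3)O2)c(=O)[nH]c1=O`: 9.47 h
Compound 2 `Cc1cn([C@H]2C[C@H](N=[N+]=[N-])[C@@H](COP(=O)(O)Oc3ccc(Cl)cc3)O2)c(=O)[nH]c1=O`: 5.5 h
Compound 3 `Cc1cn([C@H]2C[C@H](N=[N+]=[N-])[C@@H](COP(=O)(O)Oc3cccnc3Cl)O2)c(=O)[nH]c1=O`: not yet measured

In a physicochemical assay for metabolic stability, read by HPLC (on this read-out lower numbers stand for a shorter-lived compound and higher numbers for a longer-lived compound), compound 2 gives 5.5 h, within the scatter of compound 1 at 9.47 h. Compound 3 has 2-chloropyridin-3-yl in place of 4-chlorophenyl on an oxygen. Within the data shown here, the only measured step, a 1.7-fold lower number from compound 1 to compound 2 (0.24 log units; within the scatter), is a chloro in place of hydrogen on an aromatic carbon and lies within the scatter. Among the measured compounds shown here, no measured step brings a hetero atom into the ring, so the guidance is weak, and no shift beyond the scatter is expected. The expected step is a 1.4-fold lower number from compound 2 to compound 3 (0.14 log units; within the scatter). Compound 3 is estimated at 4 h, with an expected range of 1.5 h to 9 h.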

Compound 3, half-life: 16.3 h
The estimate for compound 3 lay 4.1-fold (0.61 log units) below the measured number, and the stated range ends below it.
By their numbers in this assay, from the lowest: compounds 2, 1 and 3 (each within the scatter of the next, the first and the last beyond it).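

At the oxygen whose other neighbour is phosphorus, the aryl group can move the half-life in this assay beyond the scatter: 2-chloropyridin-3-yl in place of 4-chlorophenyl gives a 3.0-fold higher number from compound 2 to compound 3 (0.47 log units; beyond the scatter). Set against phenyl, the same group gives a 1.7-fold higher number from compound 1 to compound 3 (0.24 log units; within the scatter), so the change is only resolved against 4-chlorophenyl. Nothing available accounts for this step.

Still open, as far as these compounds go, is whether the ring nitrogen or the place of the chloro carries the step, as the two change together. A pyridin-3-yl without chloro, or an amine in place of the chloro, would bear on this.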